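Coumarin chalcone series: 2,5-dimethoxyphenyl in place of 4-methoxyphenyl

The source may report more compounds than this note shows. Statements on the series, on what has been measured and on what is new or still open speak of the compounds shown alone.

Compound 1 `COc1ccc(/C=C/C(=O)c2cc3ccc(OCc4cccc(OC)c4)cc3oc2=O)cc1` is the reference point for this step. In a functional assay on MOLT-4 cells (Homo sapiens) for cytotoxicity, read by MTT assay, with a stated time of 72 h (a higher number here means a weaker inhibitor, a lower number a stronger inhibitor), compound 1 returns only a limit, > 100000 nM, so its position is known no more closely than the limit of > 100000 nM in this assay, at which 1 of the 2 values shown sits, allows. Compound 2 `COC(=O)c1ccc(/C=C/C(=O)c2cc3cc(O)ccc3oc2=O)cc1` carries a different core substitution pattern and is measured in this assay at 7100 nM; no one-step path connects it to compound 1, so its value stands on its own. Compound 3 `COc1cccc(COc2ccc3cc(C(=O)/C=C/c4cc(OC)ccc4OC)c(=O)oc3c2)c1` is the untested partner of compound 1. The change is 2,5-dimethoxyphenyl in place of 4-methoxyphenyl on a double-bonded chain carbon bound to a double-bonded chain carbon. For the measured compounds named here, no measured step of this kind exists here, and the step from compound 1 to compound 3 is expected to be none beyond the scatter, a number no higher from compound 1 to compound 3 (the limit leaves the size open). Compound 3 is therefore estimated at 100000 nM, within 30000 nM to 300000 nM, most likely again as a limit.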

Compound 3, half-maximal inhibitory concentration: 13800 nM
Compound 3: middle estimate off by 7.2-fold (0.86 log units), on the high side, outside the stated range (below it).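

For the compounds shown here, this is the first measured step at this place, on a double-bonded chain carbon bound to a double-bonded chain carbon, and it shows that the aryl group there affects the reading while the rest of compound 1 stays fixed. In this assay, 2,5-dimethoxyphenyl in place of 4-methoxyphenyl gives an at least 7.2-fold lower number from compound 1 to compound 3 (0.86 log units; beyond the scatter). Compound 1 is only a limit, so this step has a lower bound and no exact size: the limit of > 100000 nM in this assay, at which 1 of the 3 values shown sits.

Going by these compounds alone, whether the shift follows from the added methoxy group or from the new arrangement of the two methoxy groups stays open, with only this one pair carrying the change. Also open, on these data alone, are how a dimethylamino group or a carboxylic acid on that phenyl ring would read, and whether the step holds on a different core.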